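Working notes: replacing the amide substituent of compound 3

A few compounds are considered here, and "the series" means these few. Any claim that something is new, unique, unknown or untested is made for them only; others in the source may bear on it.

Measured in an ADME assay on microsomes from liver (Mus musculus, strain CD-1) for metabolic stability, read by LC-MS, tested at 2 uM; a higher number here means that the compound lasts longer, a lower number that the compound disappears faster:
- compound 1 `CN1CCC(CNS(=O)(=O)c2ccccc2Nc2cc(-c3ccc4ccn(C)c4c3)c3nccnc3c2)C1` gives 0.633 h
- compound 2 `Cn1ccc2ccc(-c3cc(Nc4ccccc4S(=O)(=O)Nc4cncnc4)cc4nccnc34)cc21` gives 0.683 h
- compound 3 `Cn1cc(CNC(=O)c2ccncc2Nc2cc(-c3ccc4ccn(C)c4c3)c3nccnc3c2)cn1` gives 0.267 h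

Compound 3 holds the lowest of the three numbers, beyond the scatter from both compound 1 and compound 2. The next analogue is compound 4 `CN1CC(NC(=O)c2ccncc2Nc2cc(-c3ccc4ccn(C)c4c3)c3nccnc3c2)CCC1=O`, with 1-methyl-6-oxopiperidin-3-yl in place of (1-methyl-1H-pyrazol-4-yl)methyl on an amide-type nitrogen.

Going by the values given here, only one measured step bears on this change, and only loosely (a 1.1-fold higher number from compound 1 to compound 2 (0.03 log units; within the scatter)). It replaces (1-methylpyrrolidin-3-yl)methyl with pyrimidin-5-yl on a sulfonamide nitrogen and stays within the scatter. Among the compounds with values here, no step on an amide-type nitrogen has been measured. A large shift in this assay is therefore not expected, and no firm direction can be assigned.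

The expected change is small and within the scatter (a 1.2-fold higher number from compound 3 to compound 4 (0.08 log units; within the scatter)).

For compound 4 the estimated half-life is 0.32 h (expected range 0.15 h to 0.7 h).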

Compound 4, half-life: 0.75 h
The estimate for compound 4 lay 2.3-fold (0.37 log units) below the measured number; measured number outside the range, above it.
By their numbers in this assay, from the lowest: compound 3; then compounds 1, 2 and 4 (each within the scatter of the next).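

The substituent on this amide-type nitrogen matters in this assay: 1-methyl-6-oxopiperidin-3-yl in place of (1-methyl-1H-pyrazol-4-yl)methyl gives a 2.8-fold higher number from compound 3 to compound 4 (0.45 log units; beyond the scatter) as the first step read at this position. Going by these compounds alone, the only earlier step, on a sulfonamide nitrogen, stayed within the scatter, so this is the first single exchange to go beyond it. Nothing available explains the step.

The exchange removes a five-membered aromatic ring and brings in a six-membered non-aromatic ring with a carbonyl, so the compounds shown do not separate these changes. Going by these compounds, whether the higher number would persist with a plain 1-methylpiperidin-3-yl lacking the carbonyl, or with a (1-methyl-6-oxopiperidin-3-yl)methyl group and its longer chain, remains open.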